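The compounds below may be only part of what the source reports. "The series", "measured", "known", "first", "only" and "open" are said of these compounds alone.

In a functional assay on K562 cells (Homo sapiens) for cytotoxicity, read by MTT assay, with a stated time of 24 h (on this read-out lower numbers stand for stronger inhibition and higher numbers for weaker inhibition), compound 1 (`COc1ccc(/C=C2\CN(C)C/C(=C\c3ccccc3F)C2=O)cc1`) gives 18400 nM. Compound 2 (`COc1ccc(/C=C2\CN(C)C/C(=C\c3ccccc3F)C2=O)cc1OC`) sits level with it at 18000 nM, so these two share the high end of the three numbers. Compound 3 (`CN1C/C(=C\c2cccc([N+](=O)[O-])c2)C(=O)/C(=C/c2ccccc2F)C1`), which carries a nitro group and no methoxy, gives a clearly lower 3890 nM, a gap beyond the scatter.

Compound 4 (`CN1C/C(=C\c2ccc(C#N)cc2)C(=O)/C(=C/c2ccccc2F)C1`) departs from compound 1 by cyano in place of methoxy on an aromatic carbon. Among the compounds with values here, the one measured single-place step, a 1.0-fold lower number from compound 1 to compound 2 (0.01 log units; within the scatter), adds a methoxy and stays within the scatter. It shows that this added methoxy changes little, but it does not test a cyano. Within the data shown here, the only other guide is compound 3 at 3890 nM, which suggests that losing the methoxy for a different group may lower the number, though that comparison is not a single-place step. A moderate move toward lower numbers is therefore expected, with real uncertainty: a 2.8-fold lower number from compound 1 to compound 4 (0.45 log units; beyond the scatter) is the estimated step. For compound 4, the estimated value in this assay is 6500 nM, within an expected range of 2500 nM to 16000 nM.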

Compound 4, half-maximal inhibitory concentration: 2670 nM
Estimate against measurement, compound 4: 2.4-fold (0.39 log units) above; the measured number falls inside the stated range.
By their numbers in this assay, from the lowest: compounds 4 and 3 (each within the scatter of the next); then compounds 2 and 1 (each within the scatter of the next).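

In this assay, exchanging the group para to a large group, 4-methoxyphenyl to 4-cyanophenyl, gives a 6.9-fold lower number from compound 1 to compound 4 (0.84 log units; beyond the scatter). The earlier step, a 1.0-fold lower number from compound 1 to compound 2 (0.01 log units; within the scatter), showed only that a further methoxy on this ring leaves the number level, whereas this result shows that the number does respond when the methoxy at this place gives way to a cyano. Nothing shown here accounts for the size of this step or says what lies behind it.

The compounds shown leave open whether the step belongs to the entering cyano or to the leaving methoxy. They also leave open how the number would stand with plain hydrogen, an amine or a carboxylic acid at this same place on the ring.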